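The compounds below may be only part of what the source reports. "The series", "measured", "known", "first", "only" and "open" are said of these compounds alone.

Compound 1, with the structure `CCN(CC)c1cc2[nH]c(C3CCCCC3)nc2cc1NC(=O)OCC(F)(F)F`, was tested in an ADME assay on Vero cells (Chlorocebus sabaeus) for cytotoxicity, read by resazurin assay, with a stated time of 3 days; a higher number here means a weaker inhibitor, a lower number a stronger inhibitor. In this assay compound 1 gives > 100 ug/mL, which is a limit of the assay and not a number. Compound 2, with the structure `CN(C)c1cc2[nH]c(C3CCCCC3)nc2cc1NC(=O)OCC(F)(F)F`, differs from compound 1 only by dimethylamino in place of diethylamino on an aromatic carbon. In this assay compound 2 gives > 100 ug/mL, again a limit. The step from a step that the two limits leave unreadable from compound 1 to compound 2 therefore cannot be read in size. Compound 3, with the structure `O=C(Nc1cc2nc(C3CCCCC3)[nH]c2cc1N1CCCC1)c1ccc(Br)cc1`, carries a different amide and a different amine. In this assay compound 3 gives > 100 ug/mL, also a limit. Within the data shown here, all that the data show is the limit of > 100 ug/mL in this assay, at which 3 of the 3 values shown sit, so no measured step in this assay has a readable size.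

Compound 4, with the structure `CCOc1ccc(C(=O)Nc2cc3nc(C4CCCCC4)[nH]c3cc2N(CC)CC)cc1`, differs from compound 1 by 4-ethoxyphenyl in place of 2,2,2-trifluoroethoxy on a carbonyl carbon. Among the measured compounds shown here, none of the measured steps bears on this change with a readable size, since each of the three values shown is a limit. Compound 4 is therefore expected to behave like compound 1, with no step beyond the scatter, which as a step that the limit leaves unreadable from compound 1 to compound 4 means an expected value in this assay for compound 4 of 150 ug/mL, in the range 50 ug/mL to 450 ug/mL, most likely reported again as a limit.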

Compound 4, half-maximal inhibitory concentration: > 100 ug/mL
Compound 4 ended at the assay's limit; the forecaster's own chance of this, stated with the estimate: 75%; the middle value lies beyond the limit too.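

In this assay compound 4 gives > 100 ug/mL, which is a limit of the assay and not a number. No step from compound 1 to compound 4 can be read in size, since both compounds sit at the same limit: the limit of > 100 ug/mL in this assay, at which 4 of the 4 values shown sit.

The compounds shown leave open whether any of them would affect these cells at concentrations beyond that limit, and whether their structural differences matter.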